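Chain extension on the shared core: compound 4 pending

This account rests on a few compounds, and the source may have more. Where it says the series, first, only, none or still open, it means among the compounds named here.

Series notes. Compound 1 `CCCC(=O)c1c(C)nn(CCCN2CCN(c3ccc(C)cc3)CC2)c(=O)c1N` gives, in a functional assay on the whole organism (Abdomen, strain Swiss) for inhibition, with Mus musculus as the target, with stated times of 30 min, 10 min and 5 min, at a dose of 40 mg/kg by the oral route (on this read-out lower numbers stand for a weaker effect and higher numbers for a stronger effect at the one dose given), a value of 32%. Compound 2 `CCCCC(=O)c1c(C)nn(CCCN2CCN(c3ccc(C)cc3)CC2)c(=O)c1N` gives in this assay 15%; the two differ by methyl in place of hydrogen on a saturated chain carbon, three bonds along the chain from a carbonyl carbon and the step is a number 17 percentage points lower from compound 1 to compound 2 (beyond the scatter). Compound 3 `C/C=C/c1c(C)nn(CCCN2CCN(c3ccc(C)cc3)CC2)c(=O)c1N` gives in this assay 63%; it differs from compound 1 by prop-1-en-1-yl in place of propylcarbonyl on an aromatic carbon, a step of a number 31 percentage points higher from compound 1 to compound 3 (beyond the scatter), and against compound 2 the step is a number 48 percentage points higher from compound 2 to compound 3 (beyond the scatter). Among these three, compound 3 stands highest.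

Compound 4 `CC/C=C/c1c(C)nn(CCCN2CCN(c3ccc(C)cc3)CC2)c(=O)c1N` is not yet measured. It differs from compound 3 by methyl in place of hydrogen on a saturated chain carbon bound to a double-bonded chain carbon. This is the same kind of change as from compound 1 to compound 2, though the place differs: there the saturated chain carbon sits three bonds along the chain from a carbonyl carbon, here it is bound to a double-bonded chain carbon, and the cores differ by the difference counted from compound 1 to compound 3. Because the earlier step was a number 17 percentage points lower from compound 1 to compound 2 (beyond the scatter), a lowering is expected from compound 3 to compound 4 of about a number 17 percentage points lower from compound 3 to compound 4 (beyond the scatter). Compound 4 is therefore estimated at 46%, between 25% and 65%.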

Compound 4, a percentage reported as inhibition, in the whole organism at one dose (the size of the read-out at that dose, not a potency): 45%
Compound 4: middle estimate off by 1 percentage points, on the high side; measured number inside the range.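

In this assay, going by these compounds alone, methyl in place of hydrogen on a saturated chain carbon bound to a double-bonded chain carbon gives a step of a number 18 percentage points lower from compound 3 to compound 4 (beyond the scatter), and the same change has a like size on the two cores: the same change on two cores in this assay, a number 17 percentage points lower (beyond the scatter) from compound 1 to compound 2 and a number 18 percentage points lower (beyond the scatter) from compound 3 to compound 4, 1 percentage points apart, within the scatter of two such steps This agreement rests on only two pairs and one change, so it supports carrying this methyl step between these two cores and no further. Replacing the carbonyl-bearing chains with but-1-en-1-yl leaves the read-out on the higher side, with steps of a number 30 percentage points higher from compound 2 to compound 4 (beyond the scatter) and a number 13 percentage points higher from compound 1 to compound 4 (beyond the scatter), but these are swaps of a whole group and do not bear on how the methyl step transfers.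

From the compounds shown here alone, whether the lowering continues with a longer chain on the alkene, or holds with an amine or a carboxylic acid at the chain end, stays open. Also open, going by these compounds, is whether the step keeps its size at other doses.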